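The compounds below may be only part of what the source reports. "The series", "measured", "known", "first", "only" and "open" are said of these compounds alone.

Measured so far:
- compound 1, `CCCCCNC(=O)c1n[nH]cc1NC(=O)c1c(OC)cccc1OC` — > 50000 nM
- compound 2, `CO[C@H]1CC[C@H](NC(=O)c2n[nH]cc2NC(=O)c2cc3ccccc3o2)CC1` — 800 nM

Both compounds were tested in an ADME assay on MRC5 cells (Homo sapiens) for inhibition, with a stated time of 72 h; on this read-out higher numbers stand for an effect only at larger amounts of compound and lower numbers for an effect already at smaller amounts. Compound 1 gives > 50000 nM, which is not a number but a limit of the assay: compound 1 stands at the limit of > 50000 nM in this assay, at which 1 of the 2 values shown sits, so its true value is not known. Compound 2 gives a number, 800 nM, in this assay. For the measured compounds named here, no single-change step links these two compounds, so their two values can only be taken as they stand.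

Compound 3, `COC(=O)c1n[nH]cc1NC(=O)c1c(OC)cccc1OC`, has not yet been measured. It differs from compound 1 in one place: methoxy in place of pentylamino on a carbonyl carbon. Because no step between measured compounds is shown, there is no measured guide to how large an effect such a change has in this assay. The expectation is that compound 3 behaves like compound 1, with no step beyond the usual scatter: a number no higher from compound 1 to compound 3 (the limit leaves the size open). Compound 3 is therefore expected to come out near 50000 nM, with a likely range from 20000 nM to 120000 nM, most probably again reported only as a limit.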

Compound 3, half-maximal effective concentration: > 50000 nM
Compound 3 gave a limit, no number (the forecaster's own chance of this, stated with the estimate: 70%); the middle value lies on the limit itself.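

Compound 1 and compound 3 each give only a limit in this assay, so no step between them can be read: the limit of > 50000 nM in this assay, at which 2 of the 3 values shown sit.

The compounds shown leave open where the true values of compound 1 and compound 3 lie, and so how much, if at all, methoxy in place of pentylamino on a carbonyl carbon shifts the read-out.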